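Hydroxy in Place of Methylsulfanylmethyl on the Chain

The compounds below may be only part of what the source reports. "The series", "measured", "known", "first", "only" and "open" are said of these compounds alone.

Measured so far:
compound 1, `CSCC[C@H](NC(=O)CN(c1nc(Cl)nc2[nH]cnc12)C1CC1)C(=O)OCc1ccccc1`: 31.6%
compound 2, `CSCC[C@H](NC(=O)CN(c1nc(Cl)nc2[nH]cnc12)C1CC1)C(=O)O`: 5.67%
compound 3, `NC(=O)C[C@H](NC(=O)CN(c1ncnc2c1ncn2C1CCCCO1)C1CC1)C(=O)OCc1ccccc1`: 29.2%

In a functional assay on the whole organism (Tail, strain ICR) with Mus musculus as the target, in the tail flick test, with a stated time of 120 min, at a dose of 25 umol/kg by the oral route (on this read-out higher numbers stand for a stronger effect at the one dose given and lower numbers for a weaker effect), compound 1 gives the highest of the three numbers, with compound 1 at 31.6%. Compound 3 stands within the scatter of it, so the two cannot be ordered. Within the data shown here, compound 2 lies clearly lower, the only single-place step in the set being a number 25.9 percentage points lower from compound 1 to compound 2 (beyond the scatter), a modest drop.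

Compound 4, `O=C(CN(c1nc(Cl)nc2[nH]cnc12)C1CC1)N[C@@H](CO)C(=O)OCc1ccccc1`, differs from compound 1 in one place: hydroxy in place of (methylsulfanyl)methyl on a saturated chain carbon, two bonds along the chain from an amide-type nitrogen and a carbonyl carbon. Among the measured compounds shown here, no measured step touches this place. The benzyl ester is kept, so the drop seen on going to the acid does not apply. Compound 3 carries a different group on the same chain carbon, and a different core, and its number is near that of compound 1; that comparison involves more than one change and is only a loose hint that the chain group may matter little. Compound 4 is therefore expected to move only slightly, a number 5.6 percentage points lower from compound 1 to compound 4 (within the scatter). Compound 4 is estimated at 26%, within 8% to 44%.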

Compound 4, a percentage reported as activity, at one dose (the size of the read-out at that dose, not a potency): 34.5%
Compound 4: middle estimate off by 8.5 percentage points, on the low side, and the stated range covers the measured number.
By their numbers in this assay, from the lowest: compound 2; then compounds 3, 1 and 4 (each within the scatter of the next).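

At this saturated chain carbon, hydroxy in place of (methylsulfanyl)methyl gives a number 2.9 percentage points higher from compound 1 to compound 4 (within the scatter) in this assay, so the two compounds cannot be ordered. Among these compounds, this is the first direct reading at this position, and it shows that, with the benzyl ester kept, the read-out at this one dose does not depend on the sulfur-bearing group or its three heavy atoms. The step stands apart from a number 25.9 percentage points lower from compound 1 to compound 2 (beyond the scatter), which lies beyond the scatter, but nothing given here explains why the chain change leaves the read-out within the scatter while the ester change does not.

The compounds shown leave open whether an amine, a methoxy group or a longer alkyl chain on this carbon would read the same way. They also leave open how hydroxy on this carbon would read alongside a free carboxylic acid in place of the benzyl ester.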